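The compounds below may be only part of what the source reports. "The series", "measured", "known", "first", "only" and "open" are said of these compounds alone.

Of the compounds shown here, three that share one core have been tested in an ADME assay on MDBK cells (Bos taurus) for cytotoxicity; a higher number here means that more compound is tolerated, a lower number that less compound is tolerated: compound 1 (`Fc1ccc(Cn2ccc3nc(-c4ccccc4)nc-3c2)cc1`), compound 2 (`Clc1ccccc1Cn1ccc2nc(-c3ccccc3)nc-2c1`) and compound 3 (`Clc1ccc(Cn2ccc3nc(-c4ccccc4)nc-3c2)cc1`). Compound 1 gives > 100000 nM, which is a limit of the assay and not a number. Compound 2 gives > 100000 nM, again a limit. Compound 3 gives > 100000 nM, also a limit, so compound 3 has no number of its own. Going by the values given here, the whole series so far comes down to one reading: the limit of > 100000 nM in this assay, at which 3 of the 3 values shown sit.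

Compound 4 (`Brc1cccc(Cn2ccc3nc(-c4ccccc4)nc-3c2)c1`) has not yet been measured. It differs from compound 3 by 3-bromophenyl in place of 4-chlorophenyl on a saturated chain carbon bound to an aromatic nitrogen, with 3-bromophenyl in place of 4-chlorophenyl on a saturated chain carbon bound to an aromatic nitrogen. The measured steps that bear on this change all alter the same substituted phenyl group: a step that the two limits leave unreadable from compound 1 to compound 2, a step that the two limits leave unreadable from compound 1 to compound 3 and a step that the two limits leave unreadable from compound 2 to compound 3. None of them has a readable size, yet none of these changes brought a compound off the limit. In this assay, no step beyond the scatter is therefore expected, in either direction. The expected change is a number no higher from compound 3 to compound 4 (the limit leaves the size open). For compound 4 the estimate is 100000 nM, with an expected range from 50000 nM to 200000 nM, and a report of only a limit is the likeliest outcome.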

Compound 4, half-maximal cytotoxic concentration: 85000 nM
Compound 4: the middle estimate sits 1.2-fold (0.07 log units) above what was measured; the measured number falls inside the stated range.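

In this assay, going by these compounds alone, compound 4 gives 85000 nM, the first number rather than a limit, which shows that a change to the phenyl group on a saturated chain carbon bound to an aromatic nitrogen can bring a reading within the range of the assay. The three earlier compounds offer only limits and not numbers. The new steps are therefore floors rather than full sizes: an at least 1.1-fold lower number from compound 3 to compound 4 (0.07 log units; that floor lies within the scatter), an at least 1.1-fold lower number from compound 2 to compound 4 (0.07 log units; that floor lies within the scatter) and an at least 1.1-fold lower number from compound 1 to compound 4 (0.07 log units; that floor lies within the scatter). All three floors lie within the scatter, so 3-bromophenyl is not shown to differ in a real way from 4-chlorophenyl or from the other two groups, and compound 4 stands apart only in having a number, with the rest of the series still at one reading: the limit of > 100000 nM in this assay, at which 3 of the 4 values shown sit.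

Going by these compounds, how far the three earlier compounds truly sit from compound 4 stays unknown, as does whether the number of compound 4 belongs to the bromine or to its place on the phenyl group. Nor do the compounds shown tell how this assay would respond to an amine or a carboxylic acid on that phenyl group, or to a longer chain carrying it.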